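The source may hold more compounds than are shown below. What is called first, only, known or untested is meant among the compounds shown, and "the series" means these compounds.

Of the compounds shown here, three that share a core have so far been measured in an ADME assay on Caco-2 cells (Homo sapiens) for permeability, in the apical to basolateral direction (a lower number here means that the compound crosses the layer more slowly, a higher number that the compound crosses the layer faster), and each result is a limit of the assay and not a number. Compound 1 `COC(=O)N[C@H](C(=O)NN(CCC[C@@](O)(Cc1ccccc1)C(=O)N[C@H]1c2ccccc2C[C@H]1O)Cc1ccc(Br)cc1)C(C)(C)C` gives > 20 10^-6 cm/s as its limit. Compound 2 `COC(=O)N[C@H](C(=O)NN(CCC[C@](O)(Cc1ccccc1)C(=O)N[C@H]1c2ccccc2C[C@H]1O)Cc1ccc(Br)cc1)C(C)(C)C` gives > 20 10^-6 cm/s as its limit. Compound 3 `COC(=O)N[C@H](C(=O)NN(CCC[C@@](O)(Cc1ccccc1)C(=O)N[C@H]1c2ccccc2C[C@H]1O)Cc1ccc(-c2ccccc2)cc1)C(C)(C)C` gives > 20 10^-6 cm/s as its limit, so its standing is known only in that form.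

Compound 4 `COC(=O)N[C@H](C(=O)NN(CCC[C@@](O)(Cc1ccccc1)C(=O)N[C@H]1c2ccccc2C[C@H]1O)Cc1ccc(-c2ccncc2)cc1)C(C)(C)C` has not yet been measured. It differs from compound 3 in one place, with pyridin-4-yl in place of phenyl on an aromatic carbon and the rest of the structure unchanged.

Going by the values given here, two measured steps bear on this. The closer one is a step that the two limits leave unreadable from compound 1 to compound 3 with phenyl in place of bromo on that same aromatic carbon. The other is a step that the two limits leave unreadable from compound 1 to compound 2 and it comes with the fact that compounds 1 and 2 differ only in the configuration as drawn so it touches a different part of the molecule. Neither step has a readable size because of the limit of > 20 10^-6 cm/s in this assay, at which 3 of the 3 values shown sit, and so neither offers a size or a direction to carry over. No step beyond the usual scatter is therefore expected in this assay for this swap. The expected result is a step that the limit leaves unreadable from compound 3 to compound 4 as an estimate only. For compound 4 the estimated value is 22 10^-6 cm/s with an expected range from 9 10^-6 cm/s to 40 10^-6 cm/s and the assay may again report only a limit.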

Compound 4, apparent permeability: < 20 10^-6 cm/s
Compound 4: no number, only a limit; the forecaster's own chance of this, stated with the estimate: 55%; middle value at least 1.1-fold (0.04 log units) from the limit.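

In this assay, compound 4 gives < 20 10^-6 cm/s, which is a limit of the assay and not a number. On this aromatic carbon, para to a large group, the group now leaves a mark on the result: with pyridin-4-yl in place of phenyl the result is a number no higher from compound 3 to compound 4 (the limit leaves the size open), and with pyridin-4-yl in place of bromo it is a number no higher from compound 1 to compound 4 (the limit leaves the size open). The earlier compounds could show no direction for any change, because all of them sat at the opposite limit: the limit of > 20 10^-6 cm/s in this assay, at which 3 of the 4 values shown sit.

On these data alone, neither step can be read for size, so it stays open how far compound 4 lies from compound 1 or compound 3, and whether the ring nitrogen of pyridin-4-yl alone accounts for the difference. Going by these compounds alone, also open is how an amine or a carboxylic acid on this same aromatic carbon would read, and whether pyridin-4-yl would give the same kind of result with the other configuration at the chain stereocentre, the one drawn in compound 2.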